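Series notes: chloro on the anilino ring of compound 3

The source may report more compounds than this note shows. Statements on the series, on what has been measured and on what is new or still open speak of the compounds shown alone.

Measured compounds in a functional assay on PC-3 cells (Homo sapiens) for cytotoxicity, read by MTT assay, with a stated time of 72 h; a lower number here means a stronger inhibitor, a higher number a weaker inhibitor:
compound 1 `O=S(=O)(c1ccccc1)c1nc2ccccc2nc1Nc1ccccc1`: 590 nM
compound 2 `Cc1ccc(S(=O)(=O)c2nc3ccccc3nc2Nc2ccccc2)cc1`: 1060 nM
compound 3 `O=S(=O)(c1ccc(Br)cc1)c1nc2ccccc2nc1Nc1ccccc1`: 1180 nM

All three share one core and differ only on the aromatic ring attached to the sulfonyl group. Compound 3 gives the highest number of the three, but the steps of a 1.1-fold higher number from compound 2 to compound 3 (0.05 log units; within the scatter) and a 2.0-fold higher number from compound 1 to compound 3 (0.30 log units; within the scatter) both sit within the scatter, so no order among the three can be read from these values. The step of a 1.8-fold higher number from compound 1 to compound 2 (0.25 log units; within the scatter) likewise lies within the scatter.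

Compound 4 `O=S(=O)(c1ccc(Br)cc1)c1nc2ccccc2nc1Nc1ccc(Cl)cc1` is not yet measured. It differs from compound 3 by chloro in place of hydrogen on an aromatic carbon, on an aromatic carbon of a six-membered aromatic ring of carbon only, para to a large group; read one bond further out, anilino becomes (4-chlorophenyl)amino. Within the data shown here, no measured step touches this ring. Among the measured compounds shown here, the only substituent steps available, on the other aromatic ring, were all within the scatter. On that basis no step beyond the scatter is expected for compound 4, with the estimated change being a 1.0-fold higher number from compound 3 to compound 4 (0.01 log units; within the scatter). Compound 4 is therefore estimated at 1200 nM, with a range from 450 nM to 3200 nM.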

Compound 4, half-maximal inhibitory concentration: 7460 nM
Compound 4: the middle estimate sits 6.2-fold (0.79 log units) below what was measured; measured number outside the range, above it.
By their numbers in this assay, from the lowest: compounds 1, 2 and 3 (each within the scatter of the next); then compound 4.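

Among these compounds, the anilino ring gives the first single change that lies beyond the scatter in this assay: chloro in place of hydrogen, on an aromatic carbon para to a large group, gives a 6.3-fold higher number from compound 3 to compound 4 (0.80 log units; beyond the scatter) and so marks compound 4 as the weaker inhibitor of the pair. The methyl and bromo steps on the ring attached to the sulfonyl group all stayed within the scatter, so among the compounds shown, only this change on the anilino ring separates two compounds, although it adds just one heavy atom. No measurement in hand accounts for the size or direction of this step.

From the compounds shown here alone, it remains open whether the step is specific to chloro or would also follow from another group at this position, such as fluoro, methyl, methoxy or an amine. Compound 4 also carries bromo on the ring attached to the sulfonyl group, so it is also unresolved whether the same chloro change would produce a similar step on compound 1, which has hydrogen there.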